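The compounds below may be only part of what the source reports. "The series", "measured", "known", "first", "only" and "open" are said of these compounds alone.

Measured in a functional assay on A549 cells (Homo sapiens) for antiproliferative activity, read by MTT assay, with a stated time of 72 h; on this read-out lower numbers stand for stronger inhibition and higher numbers for weaker inhibition:

Compound 1 `O=C1COc2ccc(-c3cccc(NS(=O)(=O)c4ccc(F)cc4)c3)cc2N1c1ccc(Cl)cc1`: 31600 nM
Compound 2 `O=C1COc2ccc(-c3cnc4ccccc4c3)cc2N1C1CCCCC1`: > 40000 nM (a limit)
Compound 3 `Cc1ccc(N2C(=O)COc3ccc(-c4cnc(Cl)c(NS(=O)(=O)c5ccc(F)cc5)c4)cc32)cc1`: 30900 nM

Only two of these three results are numbers. Compound 1 gives 31600 nM and compound 3 gives 30900 nM, and these two values lie within the usual scatter of each other. Compound 1 therefore stands level with compound 3. Compound 2 returned only a limit, > 40000 nM, and not a number.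

The next compound to be tested is compound 4 `COc1ccc(N2C(=O)COc3ccc(-c4cccc(NS(=O)(=O)c5ccc(F)cc5)c4)cc32)cc1`, which has not yet been measured. It departs from compound 1 by a single change, methoxy in place of chloro on an aromatic carbon, para to a large group, so that 4-chlorophenyl becomes 4-methoxyphenyl.

Within the data shown here, no pair of measured compounds shows this change alone, so there is no direct precedent for its size. Starting from compound 1 at 31600 nM, no step beyond the scatter is expected in this assay. A result that gives only a limit remains possible, and compound 2 shows that outcome: the limit of > 40000 nM in this assay, at which 1 of the 3 values shown sits. The expected change is a 1.1-fold lower number from compound 1 to compound 4 (0.05 log units; within the scatter). The estimate for compound 4 is 28000 nM, with an expected range from 12000 nM to 40000 nM.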

Compound 4, half-maximal inhibitory concentration: 38200 nM
The estimate for compound 4 lay 1.4-fold (0.13 log units) below the measured number; low and high end bracket the measured number.
By their numbers in this assay, from the lowest: compounds 3, 1 and 4 (each within the scatter of the next). At a limit, above all of these: compound 2.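

In this assay, the step from chloro to methoxy gives the first direct reading of a single change among these compounds, and it is small (a 1.2-fold higher number from compound 1 to compound 4 (0.08 log units; within the scatter)). With 4-chlorophenyl becoming 4-methoxyphenyl, compound 4 stands level with compound 1, so at this place, para to a large group, the read-out does not separate the two groups, even though methoxy brings one more heavy atom and a hydrogen-bond acceptor that chloro does not have. Nothing in the data shown offers a reason for this outcome.

The compounds shown leave open whether any other group at this place, such as an amine, a carboxylic acid or a longer chain, would give a step beyond the scatter in either direction. Among these compounds, they also leave open whether the exchange of chloro for methoxy would read the same on a compound that differs elsewhere from compound 1, as this pair is the only single-place comparison available here.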